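This account rests on a few compounds, and the source may have more. Where it says the series, first, only, none or still open, it means among the compounds named here.

Compound 2 `O=C(/C(=C\c1ccc(F)cc1F)S(=O)(=O)c1ccc(Cl)cc1)c1ccc(Br)cc1` is the weaker of two measured growth inhibitors. In a functional assay on DU-145 cells (Homo sapiens) for inhibition, read by trypan blue exclusion, with a stated time of 96 h (a lower number here means a stronger inhibitor of growth, a higher number a weaker inhibitor of growth), compound 2 gives 25000 nM, the higher number, while compound 1 `COc1ccccc1/C=C(\C(=O)c1ccc(Br)cc1)S(=O)(=O)c1ccc(C)cc1` gives 1000 nM, a gap beyond the scatter.

Compound 3 `Cc1ccc(S(=O)(=O)/C(=C/c2ccc(F)cc2F)C(=O)c2ccc(Br)cc2)cc1` departs from compound 2 in one place: methyl in place of chloro on an aromatic carbon. This puts methyl in place of chloro on an aromatic carbon, so 4-chlorophenyl becomes 4-methylphenyl.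

Within the data shown here, no measured pair isolates this change, since compound 1 and compound 2 differ in more than one place. Compound 1 does carry the 4-methylphenyl group and gives 1000 nM, which is only a weak hint toward a lower number. A moderate step toward stronger inhibition is therefore expected, a 3.1-fold lower number from compound 2 to compound 3 (0.49 log units; beyond the scatter), though it may not clear the scatter. For compound 3 the estimated value is 8000 nM, with an expected range from 1500 nM to 30000 nM.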

Compound 3, concentration for 50% growth inhibition: > 100000 nM
Compound 3: no number, only a limit (the forecaster's own chance of this, stated with the estimate: 10%); at least 12-fold (1.09 log units) between middle value and limit.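

In this assay the entry for compound 3 is a limit of the assay and not a number: the limit of > 100000 nM in this assay, at which 1 of the 3 values shown sits. Even so, the change from 4-chlorophenyl to 4-methylphenyl, on an aromatic carbon para to a large group, gives an at least 4.0-fold higher number from compound 2 to compound 3 (0.60 log units; beyond the scatter), so with the 2,4-difluorophenyl group present, this swap of a single heavy atom moves the result toward weaker inhibition of growth. With 4-methylphenyl held fixed, 2,4-difluorophenyl in place of 2-methoxyphenyl gives an at least 100-fold higher number from compound 1 to compound 3 (2.00 log units; beyond the scatter), which shows that the 4-methylphenyl group alone does not secure the stronger inhibition seen for compound 1.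

From the compounds shown here alone, whether the change from chloro to methyl would run the same way alongside the 2-methoxyphenyl group stays open. So does how an amine or a carboxylic acid on the same aromatic carbon would read, and how large the steps to compound 3 truly are.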